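Acetyl to oxime: expected tolerance of compound 3

The source may hold more compounds than are shown below. What is called first, only, known or untested is meant among the compounds shown, and "the series" means these compounds.

compound 1, `COc1ccc(-c2nc3cc(C(C)=O)ccc3[nH]2)c(OC)c1`: 50000 nM
compound 2, `COc1ccc(-c2nc3cc(C(C)=O)ccc3[nH]2)c(OC)c1OC`: > 100000 nM
compound 3, `COc1ccc(-c2nc3cc(/C(C)=N/O)ccc3[nH]2)c(OC)c1`: not yet measured

Within the data shown here, in an ADME assay on BHK-21 cells (Mesocricetus auratus) for cytotoxicity, read by MTT assay (a lower number here means that less compound is tolerated, a higher number that more compound is tolerated), compound 1 stands as the only plain number among the values shown. For compound 2 this assay returns only a limit, (the limit of > 100000 nM in this assay, at which 1 of the 2 values shown sits). Among the measured compounds shown here, the one measured step, an at least 2.0-fold higher number from compound 1 to compound 2 (0.30 log units; that floor lies within the scatter), concerns methoxy on an aromatic carbon and does not touch the change at hand. Compound 3 differs from compound 1 by a group of 4 heavy atoms (2 carbon, 1 nitrogen, 1 oxygen; no ring) in place of a group of 3 heavy atoms (2 carbon, 1 oxygen; no ring), on an aromatic carbon: the acetyl leaves. For the measured compounds named here, no measured step bears on this position, so no shift beyond the scatter is expected. The expected step is a 1.2-fold higher number from compound 1 to compound 3 (0.08 log units; within the scatter). Compound 3 is estimated at 60000 nM, between 25000 nM and 150000 nM.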

Compound 3, half-maximal cytotoxic concentration: > 100000 nM
Compound 3 gave a limit, no number (the forecaster's own chance of this, stated with the estimate: 35%); at least 1.6-fold (0.22 log units) between middle value and limit.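

In this assay, among these compounds, exchanging the acetyl for the oxime on this aromatic carbon gives an at least 2.0-fold higher number from compound 1 to compound 3 (0.30 log units; that floor lies within the scatter), the first reading at this position of the shared core. Compound 3 returns a limit and not a number, so the size of the change remains unread, and no drop in tolerance appears with this exchange. Compound 3 now joins the other result reported only as a limit: the limit of > 100000 nM in this assay, at which 2 of the 3 values shown sit.

From the compounds shown here alone, the actual number for compound 3 remains open. So does whether an amine, a carboxylic acid or a longer chain at this position would keep tolerance at this level.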